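Turning a Third Stereocentre in a Cyclic Peptide

This account rests on a few compounds, and the source may have more. Where it says the series, first, only, none or still open, it means among the compounds named here.

Compound 1 `N=C(N)NCCC[C@@H]1NC(=O)CC(=O)N[C@@H](CC(=O)O)C(=O)N[C@@H](Cc2ccccc2)CNC1=O` is a cyclic peptide with four stereocentres. In an assay on K562 cells for inhibition of integrin alpha-5/beta-1 (Homo sapiens), with a stated time of 30 min (on this read-out lower numbers stand for stronger inhibition and higher numbers for weaker inhibition), compound 1 gives 520 nM. Compound 2 `N=C(N)NCCC[C@H]1NC(=O)CC(=O)N[C@@H](CC(=O)O)C(=O)N[C@@H](Cc2ccccc2)CNC1=O` has the same atoms and bonds, with one stereocentre at a saturated ring carbon drawn the other way; in this assay compound 2 gives 4700 nM, and the step is a 9.0-fold higher number from compound 1 to compound 2 (0.96 log units; beyond the scatter). Compound 3 `N=C(N)NCCC[C@@H]1NC(=O)CC(=O)N[C@H](CC(=O)O)C(=O)N[C@@H](Cc2ccccc2)CNC1=O` differs from compound 1 at a different ring stereocentre. For compound 3 this assay reports only a limit, > 100000 nM. The step of an at least 190-fold higher number from compound 1 to compound 3 (2.28 log units; beyond the scatter) is accordingly a bound rather than a number, as is an at least 21-fold higher number from compound 2 to compound 3 (1.32 log units; beyond the scatter). Compound 3 thus sits at the weak end of everything measured here.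

Compound 4 `N=C(N)NCCC[C@@H]1NC(=O)CC(=O)N[C@H](CC(=O)O)C(=O)N[C@H](Cc2ccccc2)CNC1=O` is reached from compound 3 by the two compounds have the same atoms and bonds; at least one stereo element is drawn with a configuration in one of them and without one in the other: 1 of 4 stereo elements differ; a stereocentre at a saturated ring carbon is drawn S in compound 3 and R in compound 4. Every change of a ring stereocentre seen so far raised the number, in one case modestly and in two cases at least largely. Among the compounds with values here, the change to compound 4 touches a third centre, one not yet varied on its own, so no measured step gives its direction, and compound 4 also keeps the inverted centre of compound 3. The number for compound 4 is therefore expected to stay near the limit, with a number no higher from compound 3 to compound 4 (the limit leaves the size open) as the estimated step. Compound 4 is estimated at 100000 nM, between 5000 nM and 300000 nM.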

Compound 4, half-maximal inhibitory concentration: 1300 nM
Beside the measured number, compound 4's estimate is 77-fold (1.89 log units) above it, outside the stated range (below it).
By their numbers in this assay, from the lowest: compound 1; then compound 4; then compound 2. At a limit, above all of these: compound 3.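

Inverting this third ring stereocentre is the first ring change here to lower the number, with an at least 76-fold lower number from compound 3 to compound 4 (1.88 log units; beyond the scatter). Compound 3 has only a limit in this assay, so that step is a bound and the true size of the recovery stays unfixed. The second inversion therefore wins back most of what the first one lost, leaving a modest gap to the starting arrangement, with a 2.5-fold higher number from compound 1 to compound 4 (0.40 log units; beyond the scatter), and even an edge over the compound inverted at a different centre, with a 3.6-fold lower number from compound 2 to compound 4 (0.56 log units; beyond the scatter), so the effect of turning one centre depends on how at least one other centre is drawn.

Going by these compounds, what inverting the third centre does on its own, with the other centres as in compound 1, stays open, and so does whether the recovery needs both inversions together. Also open, on these data alone, is how the number would respond if the phenyl ring gave way to a cyclohexyl ring, or the carboxylic acid to a tetrazole, in the arrangement of compound 4.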